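Compound 3: Methoxy in Place of Iodo

The source may report more compounds than this note shows. Statements on the series, on what has been measured and on what is new or still open speak of the compounds shown alone.

In an ADME assay on MCF-10A cells (Homo sapiens) for cytotoxicity, read by WST assay, with a stated time of 48 h (on this read-out lower numbers stand for stronger inhibition and higher numbers for weaker inhibition), compound 2 `O=C(NNC(=S)Nc1ccc(I)cc1)c1ccncc1` gives > 300000 nM, which is a limit and not a number. Compound 1 `CCOc1ccc(NC(=S)NNC(=O)c2ccncc2)cc1` gives > 300000 nM, also a limit. Among the measured compounds shown here, the one measured step is a step that the two limits leave unreadable from compound 1 to compound 2, and the only evidence on it is the limit of > 300000 nM in this assay, at which 2 of the 2 values shown sit. Compound 3 `COc1ccc(NC(=S)NNC(=O)c2ccncc2)cc1` has methoxy in place of iodo on an aromatic carbon, para to a large group (methoxy in place of iodo on an aromatic carbon). With a step that the two limits leave unreadable from compound 1 to compound 2 giving no size, no step beyond the scatter is expected in this assay, and no direction can be expected. The estimated change is a number no higher from compound 2 to compound 3 (the limit leaves the size open). Compound 3 is expected at 300000 nM, within an estimated range of 120000 nM to 600000 nM.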

Compound 3, half-maximal inhibitory concentration: 47500 nM
Estimate against measurement, compound 3: 6.3-fold (0.80 log units) above; measured number outside the range, below it.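

Methoxy gives the only readable number shown in this assay, so the group at this place, para to a large group, can move the result off the limit. Methoxy in place of iodo gives an at least 6.3-fold lower number from compound 2 to compound 3 (0.80 log units; beyond the scatter), and methoxy in place of ethoxy gives an at least 6.3-fold lower number from compound 1 to compound 3 (0.80 log units; beyond the scatter), so a single methyl separates a number from a limit. Both steps are open-ended in size: the limit of > 300000 nM in this assay, at which 2 of the 3 values shown sit.

On these data alone, whether an amine or a carboxylic acid at this place would also give a readable number stays open. So does whether hydrogen there would lie nearer to methoxy or to ethoxy.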